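Moving from a fluorophenoxy to a nitrile-bearing benzyl group

The source may report more compounds than this note shows. Statements on the series, on what has been measured and on what is new or still open speak of the compounds shown alone.

Measured compounds:
compound 1 `CC(C)(Oc1ccc(F)cc1)C1OCC(C/C=C\CCC(=O)O)C(c2cccnc2)O1` — 2000 nM
compound 2 `CC(C)(Oc1ccccc1F)C1OCC(C/C=C\CCC(=O)O)C(c2cccnc2)O1` — < 1000 nM

Among the measured compounds shown here, in an assay for inhibition of prostacyclin synthase (Homo sapiens), using microsomes (a lower number here means a stronger inhibitor, a higher number a weaker inhibitor), compound 1 gives 2000 nM, the only full number among the two values shown. For compound 2 the assay reports a limit, < 1000 nM, so (the limit of < 1000 nM in this assay, at which 1 of the 2 values shown sits). For the measured compounds named here, the one measured step, an at least 2.0-fold lower number from compound 1 to compound 2 (0.30 log units; that floor lies within the scatter), moves the fluorine on the ring and says little about the change to compound 3 `CC(C)(Cc1ccc(F)cc1C#N)C1OCC(C/C=C\CCC(=O)O)C(c2cccnc2)O1`, which is a group of 10 heavy atoms (8 carbon, 1 nitrogen, 1 fluorine; one six-membered aromatic ring of carbon only) in place of a group of 8 heavy atoms (6 carbon, 1 oxygen, 1 fluorine; one six-membered aromatic ring of carbon only), on a saturated chain carbon bound to two saturated chain carbons and a saturated ring carbon. Going by the values given here, with no step that matches this change, no shift beyond the scatter is expected, and compound 3 is estimated at 2000 nM, between 500 nM and 8000 nM, which means an expected step of no change at the digits printed from compound 1 to compound 3 (within the scatter).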

Compound 3, half-maximal inhibitory concentration: 7000 nM
The estimate for compound 3 lay 3.5-fold (0.54 log units) below the measured number; the range from low to high includes it.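

In this assay, the group on this saturated chain carbon matters: exchanging the 4-fluorophenoxy for the nitrile-bearing benzyl group gives a 3.5-fold higher number from compound 1 to compound 3 (0.54 log units; beyond the scatter), whereas the earlier step only moved the fluorine on the ring. The same exchange gives an at least 7.0-fold higher number from compound 2 to compound 3 (0.84 log units; beyond the scatter). Compound 2 carries a limit and not a number: the limit of < 1000 nM in this assay, at which 1 of the 3 values shown sits.

The exchange removes the oxygen and adds the nitrile in one move, so the compounds shown do not separate the two. Going by these compounds, a plain benzyl group without the nitrile, or a phenoxy group bearing a nitrile, remains open.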